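A few compounds are considered here, and "the series" means these few. Any claim that something is new, unique, unknown or untested is made for them only; others in the source may bear on it.

Measured compounds in a functional assay on CHO-K1 cells for antagonist activity at transient receptor potential cation channel subfamily V member 1 (Homo sapiens), read by FLIPR; on this read-out lower numbers stand for stronger inhibition and higher numbers for weaker inhibition:
compound 1 `CC(C(=O)NCc1ccc(C(F)(F)F)nc1NCc1ccc(Cl)cc1)c1ccc(NS(C)(=O)=O)c(F)c1`, 414 nM
compound 2 `CC(C(=O)NCc1ccc(C(F)(F)F)nc1N1CCC(Cc2ccc(F)c(F)c2)CC1)c1ccc(NS(C)(=O)=O)c(F)c1`, 30 nM
compound 3 `CC(C(=O)NCc1ccc(C(F)(F)F)nc1N1CCC(Cc2cc(F)cc(F)c2)CC1)c1ccc(NS(C)(=O)=O)c(F)c1`, 24 nM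

Compound 3 gives the lowest of the three numbers in this assay. Its value lies close to that of compound 2, as the step of a 1.3-fold lower number from compound 2 to compound 3 (0.10 log units; within the scatter) shows, which is within the scatter; compound 1, whose value is far higher, lies beyond it. Compound 4 `CC(C(=O)NCc1ccc(C(F)(F)F)nc1N1CCC(C(F)(F)F)CC1)c1ccc(NS(C)(=O)=O)c(F)c1` differs from compound 3 by trifluoromethyl in place of 3,5-difluorobenzyl on a saturated ring carbon. Among the measured compounds shown here, no measured step covers this change: the single step among the measured compounds exchanges one difluorophenyl pattern for another and is within the scatter, while compound 1 differs at this side of the core in a different way. Because compound 1 gives 414 nM without the saturated ring and its benzyl arm, a weaker result is expected for compound 4, a step of an 8.3-fold higher number from compound 3 to compound 4 (0.92 log units; beyond the scatter). The estimate for compound 4 is 200 nM, between 50 nM and 800 nM.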

Compound 4, half-maximal inhibitory concentration: 31 nM
For compound 4 the middle estimate is 6.5-fold (0.81 log units) above the measured one; the whole stated range lies above it.
By their numbers in this assay, from the lowest: compounds 3, 2 and 4 (each within the scatter of the next); then compound 1.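

In this assay, with trifluoromethyl on the saturated ring carbon the number stays within the scatter of both difluorobenzyl compounds (a 1.3-fold higher number from compound 3 to compound 4 (0.11 log units; within the scatter); a 1.0-fold higher number from compound 2 to compound 4 (0.01 log units; within the scatter)), so among these compounds the aromatic ring of that arm is not required for such values. The large step lies instead with 4-(trifluoromethyl)piperidin-1-yl in place of (4-chlorobenzyl)amino on an aromatic carbon (a 13-fold lower number from compound 1 to compound 4 (1.13 log units; beyond the scatter)). Nothing available explains why these changes have these sizes. The compounds shown leave open how a methyl, a hydroxyl or a carboxylic acid on that ring carbon would read here.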